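Methoxy on the benzyl arm: compound 3 to compound 4

This account rests on a few compounds, and the source may have more. Where it says the series, first, only, none or still open, it means among the compounds named here.

Compound 1 `CN(C)CCn1nc(Cc2ccc(Cl)cc2)c2ccccc2c1=O` in an assay for binding affinity to Alpha-1B adrenergic receptor (Homo sapiens); on this read-out higher numbers stand for weaker inhibition and lower numbers for stronger inhibition: compound 1 gives 200 nM
Compound 2 `CCCCCc1nn(C[C@H]2CCCN2C)c(=O)c2ccccc12`: compound 2 gives 1000 nM
Compound 3 `CN1CCC[C@@H]1Cn1nc(CCc2ccccc2)c2ccccc2c1=O`: compound 3 gives 200 nM

Compound 3 stands level with compound 1 at the digits shown, the two together giving the lowest numbers; compound 2 is the furthest away, its number higher by the step of a 5.0-fold lower number from compound 2 to compound 3 (0.70 log units; beyond the scatter), which is beyond the scatter. Compound 4 `COc1ccc(Cc2nn(C[C@H]3CCCN3C)c(=O)c3ccccc23)cc1` differs from compound 3 by 4-methoxyphenyl in place of benzyl on a saturated chain carbon bound to an aromatic carbon. Among the compounds with values here, the only measured step, from compound 2 to compound 3, exchanged an aromatic ring for a chain and says little about adding a methoxy to a ring already present; no measured pair probes that. With nothing bearing on it, the step of no change at the digits printed from compound 3 to compound 4 (within the scatter) is expected to stay within the scatter. Compound 4 is therefore estimated at 200 nM, between 70 nM and 600 nM.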

Compound 4, inhibition constant: 158 nM
For compound 4 the middle estimate is 1.3-fold (0.10 log units) above the measured one, within the range that was stated.
By their numbers in this assay, from the lowest: compounds 4, 1 and 3 (each within the scatter of the next); then compound 2.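

In this assay, the change read as phenethyl to 4-methoxybenzyl brings a 1.3-fold lower number from compound 3 to compound 4 (0.10 log units; within the scatter), so this position takes the new group without a shift that can be told from the scatter. Against the butyl of compound 2, the 4-methoxyphenyl gives a 6.3-fold lower number from compound 2 to compound 4 (0.80 log units; beyond the scatter), so a second aromatic-bearing arm also stands clear of the alkyl chain. Nothing available accounts for either step. The methoxy and the shorter link changed together, so their separate contributions remain unresolved. As far as these compounds go, whether an amine or a carboxylic acid in place of the methoxy would hold this level also stays open.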